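The source may hold more compounds than are shown below. What is called first, only, known or untested is meant among the compounds shown, and "the series" means these compounds.

Working notes on the series. All three measured compounds carry a hydroxycarbamoyl end on a seven-carbon chain and were read in an assay on isolated protein for inhibition of protein deacetylase HDAC6 (Homo sapiens), read by fluorescence; a higher number here means a weaker inhibitor, a lower number a stronger inhibitor. Compound 1 `Cn1cc(-c2ccccc2Oc2ccccc2)c2cc(C(=O)NCCCCCCC(=O)NO)[nH]c2c1=O` gives 4.7 nM in this assay and stands second highest of the three numbers. Its nearest neighbour is compound 2 `O=C(CCCCCCC(=O)Nc1cnc(N(c2ccccc2)c2ccccc2)nc1)NO`, which gives 4.4 nM in this assay, within the scatter of compound 1. Furthest is compound 3 `Cn1cc(-c2cc(C(C)(C)O)ccc2Oc2ccc(F)cc2F)c2cc(C(=O)NCCCCCCC(=O)NO)[nH]c2c1=O`, which gives 8.7 nM in this assay, also within the scatter of compound 1. No pair among these three differs in a single place, so no step between measured compounds is available.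

Compound 4 `Cn1cc(-c2ccccc2Oc2ccccc2)c2cc(C(=O)NCCCCCCC(=O)Nc3ccccc3N)[nH]c2c1=O` is not yet measured. It differs from compound 1 by 2-aminophenyl in place of hydroxy on an amide-type nitrogen. No compound shown carries a (2-aminophenyl)carbamoyl end, so the step is not anchored by any measured pair; the three hydroxycarbamoyl compounds sit close together in this assay and say nothing about what follows the exchange. The expectation for this assay is a step well beyond the scatter, towards a higher number, of the size a 320-fold higher number from compound 1 to compound 4 (2.50 log units; beyond the scatter). Compound 4 is expected to give about 1500 nM in this assay, with a plausible range from 200 nM to 10000 nM.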

Compound 4, half-maximal inhibitory concentration: > 500 nM
Compound 4 ended at the assay's limit (the forecaster's own chance of this, stated with the estimate: 25%); the middle value is on the limit's open side.
By their numbers in this assay, from the lowest: compounds 2, 1 and 3 (each within the scatter of the next). At a limit, above all of these: compound 4.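

Among the compounds shown here, the exchange of hydroxy for 2-aminophenyl on an amide-type nitrogen gives the first single-place step, and in this assay it reads as an at least 100-fold higher number from compound 1 to compound 4 (2.02 log units; beyond the scatter), so this position does not tolerate every exchange, at least on the core of compound 1. In this assay compound 4 gives > 500 nM, which is a limit of the assay and not a number. The step therefore fixes only a floor for the change, and its full size stays unknown: the limit of > 500 nM in this assay, at which 1 of the 4 values shown sits.

The compounds shown leave open whether the 2-aminophenyl exchange gives a step of like size on the core of compound 2 or compound 3, and how compound 4 would read in an assay with no limit in this range. They also leave open how a smaller exchange at the same place would read, such as methoxy or an amine in place of hydroxy, and whether a carboxylic acid in place of the hydroxycarbamoyl end or a longer chain would stay close to compound 1.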